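This account rests on a few compounds, and the source may have more. Where it says the series, first, only, none or still open, it means among the compounds named here.

Of the compounds shown here, three have been measured in an assay on VSM-A10 cells for antagonist activity at Endothelin-1 receptor (Rattus norvegicus); on this read-out higher numbers stand for weaker inhibition and lower numbers for stronger inhibition. Compound 1 `Cc1noc(NS(=O)(=O)c2ccc(NCc3ccccc3)cc2)c1C` gives 9800 nM in this assay. Compound 2 `Cc1noc(NS(=O)(=O)c2cccc([N+](=O)[O-])c2)c1C` gives 7800 nM, and compound 3 `Cc1noc(NS(=O)(=O)c2cccc3c(N(C)C)cccc23)c1-c1ccccc1` gives 15900 nM. Among these three numbers compound 1 stands in the middle; its nearest neighbour is compound 2, whose value lies within the usual scatter of it, and its furthest is compound 3, whose value also lies within the scatter. All three compounds thus sit in the same weak range, and no difference beyond the scatter is seen between any two of them.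

Compound 4 `Cc1noc(NS(=O)(=O)c2ccc(N/C(S)=N/c3ccccc3)cc2)c1C` has not yet been measured. It differs from compound 1 in one place: a group of 9 heavy atoms (7 carbon, 1 nitrogen, 1 sulfur; one six-membered aromatic ring of carbon only) in place of a group of 7 heavy atoms (7 carbon; one six-membered aromatic ring of carbon only), on a nitrogen on an aromatic ring. Among the measured compounds shown here, no step between two measured compounds of this kind is available for comparison, so the expectation for compound 4 rests only on the weak range that compound 1, compound 2 and compound 3 share. The step is expected to be small, with at most a slight move towards stronger inhibition, and a 1.4-fold lower number from compound 1 to compound 4 (0.15 log units; within the scatter) expresses this. Compound 4 is therefore estimated at 7000 nM in this assay, with a range from 2000 nM to 25000 nM.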

Compound 4, half-maximal inhibitory concentration: 4100 nM
Compound 4: the middle estimate sits 1.7-fold (0.23 log units) above what was measured; measured number inside the range.
By their numbers in this assay, from the lowest: compounds 4, 2, 1 and 3 (each within the scatter of the next, the first and the last beyond it).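

Among the compounds shown here, the nitrogen on an aromatic ring in compound 1 is a place where a change of substituent can register in this assay: exchanging the benzyl for the group of 9 heavy atoms gives a 2.4-fold lower number from compound 1 to compound 4 (0.38 log units; beyond the scatter), the first single-place step to lie beyond the scatter. The entering group differs from benzyl at once in its sulfur, its nitrogen, its double bond outside the aromatic ring and its hydrogen-bond donor and acceptor, so this one step cannot assign the change to any of these features. No available measurement bears on the origin of the step.

The compounds shown leave open whether the oxygen counterpart of the entering group, a urea, would give a similar number. They also leave open whether a simple amide on the same nitrogen, or a substituent on the terminal benzene ring, would move the number further in either direction.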